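The compounds below may be only part of what the source reports. "The series", "measured", "known", "first", "only" and "open" are said of these compounds alone.

Working notes on the series. Compound 1 `COC(=O)c1cc(=O)c2c(OC)cc(OC)cc2n1S(=O)(=O)c1ccc(C)cc1` carries the shared core with a methyl ester and a tolylsulfonyl group; in a functional assay on SUP-B15 cells (Homo sapiens) for antiproliferative activity, with a stated time of 72 h (on this read-out higher numbers stand for an effect only at larger amounts of compound and lower numbers for an effect already at smaller amounts), compound 1 gives 9700 nM. Compound 2 `COc1ccc(-c2cc(=O)c3c(OC)cc(OC)cc3n2S(=O)(=O)c2ccc(F)cc2)cc1` carries instead a 4-methoxyphenyl group and a (4-fluorophenyl)sulfonyl group. For compound 2 this assay reports only a limit, > 65500 nM, not a number. Going by the values given here, of the two values shown, compound 2 sits at that limit, as the limit of > 65500 nM in this assay, at which 1 of the 2 values shown sits, records, and compound 1 is the only one with a number. Among the compounds with values here, compounds 1 and 2 differ in two places, so their two values are stated side by side and no step between them is read.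

Compound 3 `COc1ccc(-c2cc(=O)c3c(OC)cc(OC)cc3n2S(=O)(=O)c2ccc(C)cc2)cc1` is not yet measured. It differs from compound 2 by methyl in place of fluoro on an aromatic carbon. Within the data shown here, compound 2 sits at a limit, so no measured step of this kind is available to size the change; the expectation is none beyond the scatter, and the most likely outcome for compound 3 is again a limit in this assay. On that basis compound 3 is estimated at 80000 nM, with a range of 20000 nM to 300000 nM, which means an expected step that the limit leaves unreadable from compound 2 to compound 3.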

Compound 3, half-maximal effective concentration: > 44800 nM
Compound 3: only a limit was reported (the forecaster's own chance of this, stated with the estimate: 70%); the middle value does not contradict the limit.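

Going by these compounds alone, with compound 3, the (4-methylphenyl)sulfonyl group is held constant against compound 1, so the change on the other aromatic carbon can be read for the first time: in this assay the series shows an at least 4.6-fold higher number from compound 1 to compound 3 (0.66 log units; beyond the scatter) for 4-methoxyphenyl in place of methoxycarbonyl. Of the compounds shown, only compound 1, with methoxycarbonyl, gives a number, whereas both compounds with 4-methoxyphenyl, compound 2 and compound 3, give only limits, now with either fluoro or methyl on the sulfonyl-bound ring. The step for methyl in place of fluoro cannot be read, since compound 2 and compound 3 both stand at limits, so the effect of that change stays unsized here.

Still open, going by these compounds, is whether the methoxycarbonyl position tolerates other groups, such as a carboxylic acid, a primary amide or an aminomethyl group, and still give a number in this assay. Also open, on these data alone, is what fluoro, or a group such as an amine, in place of methyl on the sulfonyl-bound ring would do when methoxycarbonyl is kept, where a change could be sized against a number.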